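A methylsulfonyl for an ethyl on the piperidine-type ring

This account rests on a few compounds, and the source may have more. Where it says the series, first, only, none or still open, it means among the compounds named here.

In a physicochemical assay for solubility, read by turbidimetry, in phosphate buffer, with a stated time of 24 h, at pH 7.4 (on this read-out lower numbers stand for lower solubility and higher numbers for higher solubility), compound 1 `CCNC(=O)Nc1nc2cc(-c3ccc(C(=O)O)nc3)cc(-c3ccccn3)c2s1` gives 50 ug/mL. Compound 2 `CCNC(=O)Nc1nc2cc(-c3cnc(N4CCC(C)(C(=O)O)CC4)nc3)cc(-c3ccccn3)c2s1` reaches > 800 ug/mL, which is a limit of the assay rather than a number. Compound 3 `CCNC(=O)Nc1nc2cc(-c3cnc(N4CCC(CC)(C(=O)O)CC4)nc3)cc(-c3ccccn3)c2s1` likewise reaches > 800 ug/mL, again a limit and not a number. The change from compound 2 to compound 3, methyl in place of hydrogen on a saturated chain carbon bound to a saturated ring carbon, gives a step that the two limits leave unreadable from compound 2 to compound 3, since both ends sit at the limit of > 800 ug/mL in this assay, at which 2 of the 3 values shown sit. Compound 3 therefore stands at the upper edge of what this assay reports, with no number beneath it to compare against.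

Compound 4 `CCNC(=O)Nc1nc2cc(-c3cnc(N4CCC(C(=O)O)(S(C)(=O)=O)CC4)nc3)cc(-c3ccccn3)c2s1` differs from compound 3 by methylsulfonyl in place of ethyl on a saturated ring carbon of a six-membered non-aromatic ring with one nitrogen, three ring bonds from the ring nitrogen. Among the compounds with values here, the only step that touches this part of the structure is the one from compound 2 to compound 3, and it cannot be read, so no size can be taken from it. Compound 4 keeps the carboxylic acid and the ring nitrogen of compound 3, and the expectation is that it, too, will reach the limit, with a number no higher from compound 3 to compound 4 (the limit leaves the size open) as the expected step. Compound 4 is thus estimated at 800 ug/mL, between 250 ug/mL and 800 ug/mL.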

Compound 4, solubility: > 800 ug/mL
Compound 4 gave a limit, no number; the forecaster's own chance of this, stated with the estimate: 70%; the middle value sits exactly at the limit.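

Compound 4 gives > 800 ug/mL in this assay and this is a limit, not a number. Within the data shown here, no step among compound 2, compound 3 and compound 4 can be read, since all three sit at the same limit: the limit of > 800 ug/mL in this assay, at which 3 of the 4 values shown sit. The compounds shown leave open whether methyl, ethyl and methylsulfonyl differ at all in this read-out beyond that limit.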